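Amide aryl variation on a shared core: nitro to methoxy

A few compounds are considered here, and "the series" means these few. Any claim that something is new, unique, unknown or untested is made for them only; others in the source may bear on it.

Three measured compounds share one core and differ only in the aryl group on the amide-type nitrogen. In a functional assay on MGC-803 cells (Homo sapiens) for inhibition, read by MTT assay, with a stated time of 72 h (a higher number here means a weaker inhibitor, a lower number a stronger inhibitor), compound 1 `O=C(CSc1nc(Nc2ccccc2)c2ccccc2n1)Nc1ccccc1F` gives 10700 nM. Compound 2 `O=C(CSc1nc(Nc2ccccc2)c2ccccc2n1)Nc1ccccc1Cl` gives 24800 nM in this assay, and compound 3 `O=C(CSc1nc(Nc2ccccc2)c2ccccc2n1)Nc1cccc([N+](=O)[O-])c1` gives 28100 nM. Compound 3 and compound 2 lie within the scatter of each other, shown by a 1.1-fold higher number from compound 2 to compound 3 (0.05 log units; within the scatter); both stand beyond the scatter from compound 1, which gives the lowest number, as a 2.3-fold higher number from compound 1 to compound 2 (0.37 log units; beyond the scatter) and a 2.6-fold higher number from compound 1 to compound 3 (0.42 log units; beyond the scatter) show.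

Compound 4 `COc1cccc(NC(=O)CSc2nc(Nc3ccccc3)c3ccccc3n2)c1` is not yet measured in this assay. It differs from compound 3 by methoxy in place of nitro on an aromatic carbon. Within the data shown here, no measured step exchanges a nitro for a methoxy, so none bears on it directly. What the series does show is that every change so far on this aryl ring moved the number only modestly, the largest being a 2.6-fold higher number from compound 1 to compound 3 (0.42 log units; beyond the scatter). A step of that size or smaller is therefore expected, with no clear direction, and most likely one within the scatter. The expected step is a 1.3-fold lower number from compound 3 to compound 4 (0.11 log units; within the scatter). Compound 4 is estimated at 22000 nM, with a range from 8000 nM to 60000 nM.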

Compound 4, half-maximal inhibitory concentration: 10000 nM
Beside the measured number, compound 4's estimate is 2.2-fold (0.34 log units) above it; the measured number falls inside the stated range.
By their numbers in this assay, from the lowest: compounds 4 and 1 (each within the scatter of the next); then compounds 2 and 3 (each within the scatter of the next).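

In this assay, among these compounds, methoxy in place of nitro on an aromatic carbon, meta to a large group, gives a 2.8-fold lower number from compound 3 to compound 4 (0.45 log units; beyond the scatter) and is the first step that changes the group while keeping its place on the ring, showing that the group at this place can by itself move the number beyond the scatter. Compound 4 also separates from the 2-chlorophenyl compound, with a 2.5-fold lower number from compound 2 to compound 4 (0.39 log units; beyond the scatter) on record, yet stays level with the 2-fluorophenyl compound, with a 1.1-fold lower number from compound 1 to compound 4 (0.03 log units; within the scatter) on record, so the two pairs now read 2-fluorophenyl and 3-methoxyphenyl at the lower level and 2-chlorophenyl and 3-nitrophenyl at the higher one, and neither ring place belongs to one level alone. Nothing measured here accounts for these differences.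

The compounds shown leave open whether other groups at this same place, such as hydroxy, ethoxy, an amine or a carboxylic acid, would stay at the level of compound 4 or return to that of compound 3. They also leave open whether methoxy keeps this level when moved to another carbon of the ring.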